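Amide-nitrogen aryl variation in a trifluoromethyl diol series

The source may report more compounds than this note shows. Statements on the series, on what has been measured and on what is new or still open speak of the compounds shown alone.

Measured so far:
compound 1 `O=C(CCCCCCNC(=O)C(O)(O)C(F)(F)F)Nc1nc2ccccc2s1` — 3390 nM
compound 2 `O=C(CCCCCCNC(=O)C(O)(O)C(F)(F)F)Nc1ccc(Br)cc1` — 3160 nM

In a functional assay on cells (Panel NCI-60 (60 carcinoma cell lines), Homo sapiens) for inhibition, read by colorimetric assay, with a stated time of 3 days (on this read-out lower numbers stand for stronger inhibition of growth and higher numbers for weaker inhibition of growth), compound 1 gives 3390 nM and compound 2 gives 3160 nM. For the measured compounds named here, compound 2 carries the lowest of the two numbers, but its only neighbour is compound 1 at a 1.1-fold lower number from compound 1 to compound 2 (0.03 log units; within the scatter), so the two compounds cannot be separated on these data.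

Compound 3 `O=C(CCCCCCNC(=O)C(O)(O)C(F)(F)F)Nc1ccc(-c2ccccc2)cc1` is the next member. It differs from compound 2 by phenyl in place of bromo on an aromatic carbon. Going by the values given here, the one measured step, a 1.1-fold lower number from compound 1 to compound 2 (0.03 log units; within the scatter), exchanges the whole aryl group on the amide-type nitrogen and says nothing direct about a substituent change on that ring; no measured pair shows a bromo against a phenyl. The expectation therefore rests only on the flat picture the two measured compounds give: both aryl variants so far land close together, and a change within the scatter, or at most a modest one in either direction, is expected for compound 3 as a 1.1-fold lower number from compound 2 to compound 3 (0.02 log units; within the scatter). Compound 3 is estimated at 3000 nM, within 1000 nM to 9000 nM.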

Compound 3, concentration for 50% growth inhibition: 3090 nM
Compound 3: the middle estimate sits 1.0-fold (0.01 log units) below what was measured; the measured number falls inside the stated range.
By their numbers in this assay, from the lowest: compounds 3, 2 and 1 (each within the scatter of the next).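

In this assay, phenyl in place of bromo on an aromatic carbon, para to a large group, gives a 1.0-fold lower number from compound 2 to compound 3 (0.01 log units; within the scatter) and so stays within the scatter, although the substituent goes from 1 heavy atom to 6 heavy atoms and brings in one six-membered aromatic ring of carbon only. For the compounds shown here, the earlier step exchanged the whole aryl group on the amide-type nitrogen, whereas this pair is the first direct reading of a substituent on the ring, and on this read-out the two substituents cannot be told apart. No supporting measurement is available to explain this flat result.

Still open, from the compounds shown here alone, is whether the picture holds for substituents of another kind on the same aromatic carbon, such as an amine or a carboxylic acid, which would test more than a bromo and phenyl pair can. Also open, going by these compounds, is how much the number depends on the other end of the molecule, for instance with a longer chain in place of the present one or a carboxylic acid in place of the trifluoromethyl diol.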